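Amide series: compound 4 after three values at the limit

A few compounds are considered here, and "the series" means these few. Any claim that something is new, unique, unknown or untested is made for them only; others in the source may bear on it.

Going by the values given here, in a functional assay on HeLa cells (Homo sapiens) for antiproliferative activity, read by MTT assay, with a stated time of 72 h (a lower number here means a stronger inhibitor, a higher number a weaker inhibitor), every member of the series so far sits at the limit. Compound 1 `O=C(Nc1ccc(Cl)c(-c2nnc3c(Cl)cccn23)c1)c1cccc(Cl)c1` gives > 100000 nM, which is a limit of the assay and not a number. Compound 2 `Cc1cc(Cl)ccc1C(=O)Nc1ccc(Cl)c(-c2nnc3c(Cl)cccn23)c1` gives > 100000 nM, likewise a limit. Compound 3 `O=C(Nc1ccc(Cl)c(-c2nnc3c(Cl)cccn23)c1)c1ccc(Cl)cc1Cl` gives > 100000 nM, again a limit. Compound 3 therefore stands where the two other values stand, at the limit of > 100000 nM in this assay, at which 3 of the 3 values shown sit.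

The steps among the measured compounds are a step that the two limits leave unreadable from compound 1 to compound 2, a step that the two limits leave unreadable from compound 1 to compound 3 and a step that the two limits leave unreadable from compound 2 to compound 3; none of them can be read, since two limits give no size. Compound 4 `O=C(Nc1ccc(Cl)c(-c2nnc3c(Cl)cccn23)c1)c1cccnc1Cl` differs from compound 3 by 2-chloropyridin-3-yl in place of 2,4-dichlorophenyl on a carbonyl carbon. The change sits on the carbonyl carbon, the same place as two of the measured steps, but those steps carry no size that could guide a prediction. Among the compounds with values here, no measured step gives ground to expect a reading that comes in below the limit. Compound 4 is therefore expected to sit at the limit once more, with a step that the limit leaves unreadable from compound 3 to compound 4 as the expected step, meaning no change that could be read in this assay. The estimate for compound 4 is 150000 nM, with a range from 50000 nM to 400000 nM.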

Compound 4, half-maximal inhibitory concentration: 87500 nM
Estimate against measurement, compound 4: 1.7-fold (0.23 log units) above, and the stated range covers the measured number.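

In this assay compound 4 gives 87500 nM as the only number among the compounds shown, so a group on this carbonyl carbon, here 2-chloropyridin-3-yl, can yield a reading inside the range of the assay, though only just. The other three compounds stay at a limit, which is not a number: the limit of > 100000 nM in this assay, at which 3 of the 4 values shown sit.

The new steps are floors only, namely an at least 1.1-fold lower number from compound 3 to compound 4 (0.05 log units; that floor lies within the scatter) and an at least 1.1-fold lower number from compound 2 to compound 4 (0.05 log units; that floor lies within the scatter) and an at least 1.1-fold lower number from compound 1 to compound 4 (0.05 log units; that floor lies within the scatter) as the third, so none of them establishes a real gain for compound 4, and the steps among compound 1, compound 2 and compound 3 still cannot be read.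

The change from 2,4-dichlorophenyl to 2-chloropyridin-3-yl alters both the ring nitrogen and the chlorine count, and the compounds shown do not separate the two. Also open, on these data alone, is how the series would read with a carboxylic acid, an amine or a longer alkyl chain on the carbonyl carbon in place of these aromatic rings, and whether any such group gives a clearly lower number.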